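Propanoyl in place of methoxymethyl carbonyl on the amide

The source may hold more compounds than are shown below. What is called first, only, known or untested is meant among the compounds shown, and "the series" means these compounds.

Compound 1 `COCC(=O)N(Cc1ccc(OC)c(O)c1)c1cc(OC)c(OC)c(OC)c1` is the reference point of this small set. In a functional assay on HCT-116 cells (Homo sapiens) for inhibition, read by MTT assay, with a stated time of 48 h (on this read-out lower numbers stand for stronger inhibition and higher numbers for weaker inhibition), compound 1 gives 230 nM, the lowest of the two numbers recorded, though only by a margin inside the scatter. Compound 3 `C/C=C/C(=O)N(Cc1ccc(OC)c(N)c1)c1cc(OC)c(OC)c(OC)c1` carries a different acyl group and an amino group in place of the hydroxyl, and compound 3 gives 300 nM, so no order between compound 1 and compound 3 can be read from these two values. Compound 2 `COc1cc(NCc2ccc(Cl)cc2)cc(OC)c1OC` lacks the acyl group altogether, and in this assay compound 2 returns only a limit, > 80000 nM. the limit of > 80000 nM in this assay, at which 1 of the 3 values shown sits, describes that limit.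

Compound 4 `CCC(=O)N(Cc1ccc(OC)c(O)c1)c1cc(OC)c(OC)c(OC)c1` is not yet measured. Its difference from compound 1 is methyl in place of methoxy on a saturated chain carbon bound to a carbonyl carbon. Among the measured compounds shown here, no measured pair in the set isolates this change, so the expectation rests on the size of the edit alone. The step of a 1.3-fold higher number from compound 1 to compound 4 (0.12 log units; within the scatter) is expected to stay within the scatter, with no direction claimed. Compound 4 is thus estimated at 300 nM, with a range from 100 nM to 900 nM.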

Compound 4, half-maximal inhibitory concentration: 61 nM
Compound 4: middle estimate off by 4.9-fold (0.69 log units), on the high side, outside the stated range (below it).
By their numbers in this assay, from the lowest: compound 4; then compounds 1 and 3 (each within the scatter of the next). At a limit, above all of these: compound 2.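

In this assay, methyl in place of methoxy on a saturated chain carbon bound to a carbonyl carbon gives a 3.8-fold lower number from compound 1 to compound 4 (0.58 log units; beyond the scatter). Among the compounds shown here, this is the only single-place step so far, and it shows that the acyl chain of the amide is sensitive to a small edit, methoxymethyl to ethyl, and that the methoxy group is not needed for compound 4 to give 61 nM. Nothing shown here gives a cause for this step.

With one step, no trend along this chain can be stated. On these data alone, whether a longer chain such as butanoyl, or an amine or a carboxylic acid on the same chain carbon, would extend or reverse the step remains open, as does whether propanoyl behaves the same with an amino group in place of the hydroxyl.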